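Cytotoxicity of a pyrazoline series: swapping the thiophene substituent

The source may hold more compounds than are shown below. What is called first, only, known or untested is meant among the compounds shown, and "the series" means these compounds.

Three compounds sharing a piperidinylphenyl group were examined in an ADME assay on PBMC cells (Homo sapiens) for cytotoxicity, with a stated time of 5 days; on this read-out lower numbers stand for stronger inhibition and higher numbers for weaker inhibition. Compound 1 `O=C(/C=C/c1ccc(N2CCCCC2)cc1)c1cccs1` reaches only the limit of the assay, > 100000 nM. Compound 2 `Cc1ccc(C2=NNC(c3ccc(N4CCCCC4)cc3)C2)s1` gives 86400 nM, and compound 3 `Cc1cc(C2=NNC(c3ccc(N4CCCCC4)cc3)C2)c(C)s1` gives 77500 nM. Among the two numbers shown, compound 3 has the lowest, with compound 2 nearest; the step of a 1.1-fold lower number from compound 2 to compound 3 (0.05 log units; within the scatter) is within the scatter, so no order between them can be stated. One further value sits at the limit (the limit of > 100000 nM in this assay, at which 1 of the 3 values shown sits).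

Compound 4 `Brc1ccc(C2=NNC(c3ccc(N4CCCCC4)cc3)C2)s1` is not yet measured. It differs from compound 3 by 5-bromothiophen-2-yl in place of 2,5-dimethylthiophen-3-yl on a carbon with a double bond to nitrogen. Among the measured compounds shown here, the only measured step that bears on this change, a 1.1-fold lower number from compound 2 to compound 3 (0.05 log units; within the scatter), exchanged one thiophene pattern for another on the same carbon and moved the number by less than the scatter. A similar exchange to a bromothiophene is therefore expected to leave this assay essentially unchanged, with no step beyond the scatter in either direction. Compound 4 is thus estimated at 75000 nM, within a range of 30000 nM to 150000 nM, which corresponds to an expected step of a 1.0-fold lower number from compound 3 to compound 4 (0.01 log units; within the scatter).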

Compound 4, half-maximal inhibitory concentration: 80000 nM
For compound 4 the middle estimate is 1.1-fold (0.03 log units) below the measured one; low and high end bracket the measured number.
By their numbers in this assay, from the lowest: compounds 3, 4 and 2 (each within the scatter of the next). At a limit, above all of these: compound 1.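

In this assay, the step to 5-bromothiophen-2-yl gives a 1.0-fold higher number from compound 3 to compound 4 (0.01 log units; within the scatter), and bromo in place of methyl on an aromatic carbon gives a 1.1-fold lower number from compound 2 to compound 4 (0.03 log units; within the scatter). The earlier step compared only two methyl-bearing thiophenes, whereas this result adds a bromine-bearing thiophene on the same carbon with a double bond to nitrogen. All three compounds remain within the scatter of one another, so neither the thiophene pattern nor the exchange of bromo for methyl separates them in this read-out.

Open, on these data alone, is whether a carboxylic acid or an amine on the thiophene, or a phenyl in its place, would give a step beyond the scatter. Compound 1 stands at a limit and offers no number for comparison: the limit of > 100000 nM in this assay, at which 1 of the 4 values shown sits.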